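The source may report more compounds than this note shows. Statements on the series, on what has been measured and on what is new or still open speak of the compounds shown alone.

Compound 3 `COc1ccc(-c2nc(CSc3cccc(Cl)c3)nc3ccsc23)cn1` in an ADME assay on cells (Homo sapiens) for cytotoxicity, read by resazurin assay, with a stated time of 5 days (on this read-out lower numbers stand for higher toxicity in this test and higher numbers for lower toxicity in this test), reaches only a limit, > 10000 nM, as the limit of > 10000 nM in this assay, at which 1 of the 3 values shown sits, records. Compound 1 `COc1ccc(-c2nc(COc3cccc(Cl)c3)nc3ccsc23)cn1` likewise stands at a limit, > 50000 nM, as the limit of > 50000 nM in this assay, at which 1 of the 3 values shown sits, shows. Compound 2 `COc1ccc(-c2nc(CC(O)c3cccc(Cl)c3)nc3ccsc23)cn1` gives 31000 nM. Going by the values given here, the single readable step, an at least 1.6-fold lower number from compound 1 to compound 2 (0.20 log units; that floor lies within the scatter), stays within the scatter, while a step that the two limits leave unreadable from compound 1 to compound 3 and a step that the limit leaves unreadable from compound 2 to compound 3 cannot be sized. Compound 4 `COc1ccc(-c2nc(CSc3ccc(F)cc3F)nc3ccsc23)cn1` carries 2,4-difluorophenyl in place of 3-chlorophenyl on a sulfur. Among the compounds with values here, no measured step touches this exchange on the sulfur, and the readable numbers show no movement beyond the scatter anywhere. A step that the limit leaves unreadable from compound 3 to compound 4 is therefore expected, meaning none beyond the scatter. Compound 4 is expected to give roughly 25000 nM, with a range from 8000 nM to 80000 nM, most probably reported again only as a limit.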

Compound 4, half-maximal cytotoxic concentration: > 50000 nM
Compound 4 ended at the assay's limit; the forecaster's own chance of this, stated with the estimate: 70%; at least 2.0-fold (0.30 log units) between middle value and limit.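

In this assay compound 4 gives > 50000 nM, which is a limit and not a number. Going by these compounds alone, with 2,4-difluorophenyl on the sulfur, the sulfanyl series therefore gives no measured cytotoxic concentration here, and its limit matches the one printed for compound 1. Within the data shown here, the one readable step, an at least 1.6-fold higher number from compound 2 to compound 4 (0.20 log units; that floor lies within the scatter), stays within the scatter, while the steps to compound 4 from compound 3 and from compound 1 cannot be read.

From the compounds shown here alone, whether any exchange on the sulfur moves this read-out beyond the scatter remains open. An amine or a carboxylic acid on the phenyl ring would test this.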